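The source may hold more compounds than are shown below. What is called first, only, known or untested is meant among the compounds shown, and "the series" means these compounds.

Compound 1, `O=C1Nc2c(ncn2Cc2ccccc2)C(C#CC2CC2)N1Cc1ccccc1`, and compound 2, `O=C1Nc2c(ncn2Cc2ccccc2)C(c2ccccc2)N1Cc1ccccc1`, share one core and differ in one group only: compound 2 carries a phenyl where compound 1 carries a 2-cyclopropylethynyl. In a functional assay on K562 cells (Homo sapiens) for cytotoxicity, read by thymidine incorporation, with a stated time of 48 h, tested at 10 ug/mL (on this read-out lower numbers stand for less inhibition and higher numbers for more inhibition at the one concentration tested (going by the name of the read-out)), compound 1 gives 98%, and in this assay compound 2 gives 90%. The step of a number 8 percentage points lower from compound 1 to compound 2 (within the scatter) lies within the scatter, so the two numbers cannot be ordered; compound 2 simply holds the smaller of the two values seen so far.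

Compound 3, `CCC1(c2ccccc2)c2ncn(Cc3ccccc3)c2NC(=O)N1Cc1ccccc1`, is the next step from compound 2: ethyl in place of hydrogen on a saturated ring carbon. Among the measured compounds shown here, no measured step bears directly on this change, since the only step known alters a different group on that carbon and stayed within the scatter. The estimate therefore keeps compound 3 close to compound 2, with the expected step of a number 5 percentage points lower from compound 2 to compound 3 (within the scatter), and with the allowance for an untested change widening the range. Compound 3 is expected to give 85%, within 60% to 98%.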

Compound 3, a percentage reported as inhibition, at one concentration (the size of the read-out at that concentration, not a potency): 80%
For compound 3 the middle estimate is 5 percentage points above the measured one; the measured number falls inside the stated range.
By their numbers in this assay, from the lowest: compounds 3, 2 and 1 (each within the scatter of the next, the first and the last beyond it).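

In this assay, among the compounds shown here, the step of a number 10 percentage points lower from compound 2 to compound 3 (within the scatter) is the first reading of a group added at this saturated ring carbon rather than exchanged for another one. With ethyl in place of hydrogen, compound 3 gives 80% at the one concentration tested, so a carbon bearing both phenyl and ethyl still goes with a high inhibition number in this cell read-out. The data offer no measurement that would account for this result.

Going by these compounds, whether a longer chain such as propyl, or a group carrying an amine or a carboxylic acid, would also stay within the scatter at this carbon remains open. Also open, on these data alone, is whether ethyl would give a similar step with 2-cyclopropylethynyl on that carbon instead of phenyl.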